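Hydroxy in place of fluoro in compound 1

The source may hold more compounds than are shown below. What is called first, only, known or untested is meant among the compounds shown, and "the series" means these compounds.

Compound 1 `COc1ccc(C2=C(c3cc(OC)c(OC)c(OC)c3)C(=O)C(OC(C)=O)C2)cc1F` was tested in an ADME assay on HEp-2 cells (Homo sapiens) for cytotoxicity, read by MTT assay, with a stated time of 72 h; a lower number here means a stronger inhibitor, a higher number a weaker inhibitor. In this assay compound 1 gives < 1 ug/mL, which is a limit and not a number. It therefore stands at the limit of < 1 ug/mL in this assay, at which 2 of the 3 values shown sit. Compound 2 `COc1ccc(C2=C(c3cc(OC)c(OC)c(OC)c3)C(=O)C(O)C2)cc1F` has a free hydroxyl where compound 1 carries its acetyl ester. Compound 2 gives < 1 ug/mL, also a limit. Compound 3 `CC(=O)OC1C/C(=N/O)C(c2ccccc2)=C1c1ccccc1` gives > 100 ug/mL, a limit at the opposite end of the range.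

Compound 4 `COc1ccc(C2=C(c3cc(OC)c(OC)c(OC)c3)C(=O)C(OC(C)=O)C2)cc1O` differs from compound 1 by a single change, (hydroxy in place of fluoro on an aromatic carbon), in which 3-fluoro-4-methoxyphenyl becomes 3-hydroxy-4-methoxyphenyl. Among the measured compounds shown here, the one measured step, a step that the two limits leave unreadable from compound 1 to compound 2, lies elsewhere in the molecule, and its size cannot be read. Compound 3 differs from compound 1 in several places, so it does not isolate this change. For the measured compounds named here, no measured step therefore bears directly on the swap of fluoro for hydroxy.

The expectation rests on the shared core and on compound 1, whose limit is < 1 ug/mL. The expected step is a step that the limit leaves unreadable from compound 1 to compound 4, which means no step beyond the scatter in this assay and no firm direction. For compound 4 the estimated value is 0.5 ug/mL, with an expected range from 0.1 ug/mL to 3 ug/mL.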

Compound 4, half-maximal inhibitory concentration: > 100 ug/mL
Compound 4: only a limit was reported (the forecaster's own chance of this, stated with the estimate: 70%); middle value at least 200-fold (2.30 log units) away from the limit.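

In this assay, hydroxy in place of fluoro on the aromatic carbon ortho to a methoxy group gives an at least 100-fold higher number from compound 1 to compound 4 (2.00 log units; beyond the scatter), the only readable step among these compounds, and it shows that this one atom on the 3-fluoro-4-methoxyphenyl group can decide the read-out while the rest of the molecule stays the same. Compound 4 gives > 100 ug/mL, which is a limit, and so it stands at the opposite end of the range from compound 1: the limit of > 100 ug/mL in this assay, at which 2 of the 4 values shown sit. Among the compounds shown here, the earlier exchange of acetyl for hydrogen on the oxygen on a saturated carbon cannot be read, so this is the first evidence that any single change on the shared core can move the value in this assay.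

The true size of the step remains open, as both of its ends are limits, and nothing shown gives a cause for it. Also open, on these data alone, is whether an amine or a chlorine atom at this aromatic carbon would follow fluoro or hydroxy, and whether the free hydroxyl of compound 2 would alter the outcome of the same exchange.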